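A Fluorine Moved Within the Same Group on Oxygen

The source may report more compounds than this note shows. Statements on the series, on what has been measured and on what is new or still open speak of the compounds shown alone.

Going by the values given here, compound 2 `Fc1cccc(O/N=C2/C=C(C#Cc3ccccn3)CCC2)n1` gives 9.15 nM in an assay on brain (strain Sprague-Dawley) for displacement of a labelled ligand from metabotropic glutamate receptor 5 (Rattus norvegicus), with a stated time of 45 min (a higher number here means a weaker inhibitor, a lower number a stronger inhibitor), the lower of the two numbers measured so far; compound 1 `Cc1cccc(C#CC2=C/C(=N/Oc3cccc(F)n3)CCC2)n1` gives 46.8 nM, and the step of a 5.1-fold lower number from compound 1 to compound 2 (0.71 log units; beyond the scatter) separates the two. Compound 3 `Fc1cccnc1O/N=C1/C=C(C#Cc2ccccn2)CCC1` differs from compound 2 by 3-fluoropyridin-2-yl in place of 6-fluoropyridin-2-yl on an oxygen. Among the compounds with values here, no measured step touches this change: the one step known concerns a methyl on another group. Compound 3 is therefore expected to sit close to compound 2, with a 1.6-fold higher number from compound 2 to compound 3 (0.21 log units; within the scatter) not beyond the scatter. The estimate for compound 3 is 15 nM, within 4 nM to 60 nM.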

Compound 3, inhibition constant: 4.01 nM
For compound 3 the middle estimate is 3.7-fold (0.57 log units) above the measured one, within the range that was stated.
By their numbers in this assay, from the lowest: compound 3; then compound 2; then compound 1.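

Moving the fluorine within the group on the oxygen is not silent in this assay: 3-fluoropyridin-2-yl in place of 6-fluoropyridin-2-yl gives a 2.3-fold lower number from compound 2 to compound 3 (0.36 log units; beyond the scatter). This place therefore responds to where the fluorine stands on the ring, even with the same atoms, which the earlier step on another group could not show. Nothing at hand gives a reason for the difference. On these data alone, whether a chlorine or a methoxy group in place of that fluorine would hold the number of compound 3 stays open, as does whether the methyl that separates compound 1 from compound 2 would have the same effect on compound 3.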